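The source may hold more compounds than are shown below. What is called first, only, known or untested is meant among the compounds shown, and "the series" means these compounds.

Compound 1 `CC(C)(C)Cc1c(-c2ccc(Cl)cc2)sc(N)c1C(=O)c1ccc(Cl)cc1` is one of three compounds that share a core and were tested in an assay on CHO cells for displacement of a labelled ligand from adenosine receptor A1 (Homo sapiens), read by scintillation counting, tested at 10 uM; on this read-out higher numbers stand for more inhibition at the one concentration tested (going by the name of the read-out) and lower numbers for less inhibition. In this assay compound 1 gives 1%. Compound 2 `CC(C)(C)Cc1c(-c2ccc(OC(F)(F)F)cc2)sc(N)c1C(=O)c1ccc(Cl)cc1` gives 1%, and compound 3 `COc1ccc(-c2sc(N)c(C(=O)c3ccc(Cl)c(Cl)c3)c2CC(C)(C)C)cc1` gives 1%, so compound 1 stands level with both at the digits printed, within the scatter of repeated measurements.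

Compound 4 `CC(C)(C)Cc1c(-c2ccsc2)sc(N)c1C(=O)c1ccc(Cl)cc1` has not yet been measured. It differs from compound 1 in one place: thiophen-3-yl in place of 4-chlorophenyl on an aromatic carbon.

Among the measured compounds shown here, the only measured step that changes a group at the same place is no change at the digits printed from compound 1 to compound 2 (within the scatter), where trifluoromethoxy in place of chloro on an aromatic carbon left the read-out unchanged. Compound 3, with a different group at that place, also sits at the same level. Nothing among these three compounds moved the read-out, so the expected step of a number 1 percentage points higher from compound 1 to compound 4 (within the scatter) is none beyond the scatter. Compound 4 is therefore estimated at 2%, with a range from -8% to 12%.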

Compound 4, a percentage reported as inhibition, at one concentration (the size of the read-out at that concentration, not a potency): 2%
Compound 4: middle estimate and measured number agree at the digits printed; low and high end bracket the measured number.
By their numbers in this assay, from the lowest: compounds 1, 2, 3 and 4 (each within the scatter of the next).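

In this assay, thiophen-3-yl in place of 4-chlorophenyl gives a number 1 percentage points higher from compound 1 to compound 4 (within the scatter). The earlier step at this place swapped only the chloro group carried on the ring for trifluoromethoxy, whereas here the whole ring changes, from a six-membered aromatic ring of carbon only to a five-membered aromatic ring with 1 sulfur, and the result still lies within the scatter. No supporting measurement bears on this result.

Open is whether a quite different group at this place, such as a carboxylic acid or a piperidine ring, would give a read-out beyond the scatter of these compounds. Also open is what replacing the neopentyl group with a shorter chain or a cyclohexyl ring would do, since all the compounds shown carry neopentyl.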